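The compounds below may be only part of what the source reports. "The series", "measured", "known", "first", "only" and "open" are said of these compounds alone.

Compound 1 `Cn1c(Cc2nn(C)c(=O)c3ccccc23)nnc1SCCCCCCCC(=O)Nc1ccc(Br)cc1Br` carries a long chain linking a thioether to an amide whose nitrogen bears a 2,4-dibromophenyl group. In an assay on isolated protein (Mus musculus) for inhibition of IL15-IL15 receptor (Homo sapiens), read by resazurin assay, with stated times of 30 min and 2.5 days (on this read-out higher numbers stand for weaker inhibition and lower numbers for stronger inhibition), compound 1 gives 1500 nM. Compound 2 `Cn1c(Cc2nn(C)c(=O)c3ccccc23)nnc1S(=O)(=O)CCCCCCCC(=O)Nc1ccc(Br)cc1Br`, in which the thioether has become a sulfone, gives 1400 nM in this assay; the two numbers sit within the scatter of each other, so neither compound can be placed above the other. Compound 3 `COc1ccc(NC(=O)CSc2nnc(Cc3nn(C)c(=O)c4ccccc34)n2C)cc1`, with a much shorter chain and a 4-methoxyphenyl group on the amide nitrogen, was reported in this assay as "not active" (no number reported). Compound 1 therefore stands at the higher of the two numbers, though only by a margin inside the scatter.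

Compound 4 `Cn1c(Cc2nn(C)c(=O)c3ccccc23)nnc1SCCCCCCCC(=O)Nc1ccccc1O` keeps the core, chain and amide of compound 1 and changes only the aryl group on the amide: 2-hydroxyphenyl in place of 2,4-dibromophenyl on an amide-type nitrogen. Among the compounds with values here, no measured pair isolates this change. Within the data shown here, the one compound without bromines on that aryl group, compound 3, showed no activity, which points toward weaker inhibition. The step from compound 1 to compound 4 is expected to be a 3.0-fold higher number from compound 1 to compound 4 (0.48 log units; beyond the scatter), beyond the scatter. For compound 4 the expected value in this assay is 4500 nM, with a range from 1500 nM to 15000 nM.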

Compound 4, half-maximal inhibitory concentration: 27000 nM
The estimate for compound 4 lay 6.0-fold (0.78 log units) below the measured number; measured number outside the range, above it.
By their numbers in this assay, from the lowest: compounds 2 and 1 (each within the scatter of the next); then compound 4.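

Within the data shown here, compound 4 supplies the first measured pair that isolates the aryl group on the amide-type nitrogen: with the core, chain and amide unchanged, 2-hydroxyphenyl in place of 2,4-dibromophenyl gives an 18-fold higher number from compound 1 to compound 4 (1.26 log units; beyond the scatter) in this assay. Inhibition in this series is therefore sensitive to the aryl group at this position, and the step is large. No measurement at hand explains why this change has so large an effect.

This single change removes both bromines and adds a hydroxyl, so the compounds shown cannot tell whether losing the bromines, gaining the hydroxyl or both drives the step. Going by these compounds, a plain phenyl group, a phenyl group with a single bromine or a 2,4-dichlorophenyl group on the same nitrogen remains open, as does the effect of chain length alone.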